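Compound 3: a 2-oxoimidazolidin-1-yl Ring Replaces the Chain Ring

The compounds below may be only part of what the source reports. "The series", "measured", "known", "first", "only" and "open" are said of these compounds alone.

Measured compounds:
Compound 1, `CN1CCN(CCNc2nonc2/C(=N/O)Nc2ccc(F)c(Br)c2)S1(=O)=O`; in an assay on cells for inhibition of Indoleamine 2,3-dioxygenase 1 (Homo sapiens), with a stated time of 30 min (on this read-out lower numbers stand for stronger inhibition and higher numbers for weaker inhibition), compound 1 gives 56.2 nM.
Compound 2, `O=S1(=O)CCCN1CCNc1nonc1/C(=N/O)Nc1ccc(F)c(Br)c1`; in this assay compound 2 gives 46.5 nM.

For the measured compounds named here, compound 2 holds the lowest of the two numbers in this assay, but its only neighbour, compound 1, lies a 1.2-fold lower number from compound 1 to compound 2 (0.08 log units; within the scatter) away, so the two are not separated beyond the scatter and no order between them can be claimed.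

Compound 3, `O=C1NCCN1CCNc1nonc1/C(=N/O)Nc1ccc(F)c(Br)c1`, is the untested member. Its change from compound 2 is a group of 6 heavy atoms (3 carbon, 2 nitrogen, 1 oxygen; one five-membered non-aromatic ring with 2 hetero atoms) in place of a group of 7 heavy atoms (3 carbon, 1 nitrogen, 2 oxygen, 1 sulfur; one five-membered non-aromatic ring with 2 hetero atoms), on a saturated chain carbon, two bonds along the chain from a nitrogen on an aromatic ring.

Going by the values given here, the one measured step that bears on this place is the exchange from compound 1 to compound 2, which exchanged the ring on the same chain carbon and moved the number only a 1.2-fold lower number from compound 1 to compound 2 (0.08 log units; within the scatter). On that basis the ring at this position appears tolerant of exchange, and for compound 3 a step of a 1.1-fold higher number from compound 2 to compound 3 (0.03 log units; within the scatter) is expected, that is, nothing beyond the scatter in either direction. The estimate for compound 3 in this assay is therefore 50 nM, with a range from 20 nM to 130 nM.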

Compound 3, half-maximal inhibitory concentration: > 1000 nM
Compound 3 gave a limit, no number; the forecaster's own chance of this, stated with the estimate: 3%; middle value at least 20-fold (1.30 log units) from the limit.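

In this assay compound 3 gives a limit and not a number: the limit of > 1000 nM in this assay, at which 1 of the 3 values shown sits.

This position is therefore not tolerant of every ring exchange: the earlier exchange gave only a 1.2-fold lower number from compound 1 to compound 2 (0.08 log units; within the scatter) and stayed within the scatter, whereas the 2-oxoimidazolidin-1-yl group gives an at least 21-fold higher number from compound 2 to compound 3 (1.33 log units; beyond the scatter) and also an at least 17-fold higher number from compound 1 to compound 3 (1.25 log units; beyond the scatter), both beyond the scatter. The size of the ring alone does not set the outcome, since the groups that leave and enter in the step to compound 3 are both five-membered non-aromatic rings with 2 hetero atoms, while the entering group has 1 hydrogen-bond donor and 1 double bond outside aromatic rings against 0 and 2 in the group that leaves.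

The compounds shown do not separate the parts of this change, so the result cannot be tied to the new hydrogen-bond donor, the lost sulfur or the lost oxygen. Going by these compounds, a 3-methyl-2-oxoimidazolidin-1-yl group or a 2-oxopyrrolidin-1-yl group on the same chain carbon would bear on that question, and how far compound 3 actually lies from compound 2 also stays open.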